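From a Fluorophenyl Carbonyl to a Pyrrolidinyl Carbonyl

The compounds below may be only part of what the source reports. "The series", "measured", "known", "first", "only" and "open" are said of these compounds alone.

Compound 2 `O=C(c1cccc(F)c1)N1CC(c2nc(-c3cccc(Cl)c3)no2)C1` and compound 1 `O=C(C1CCCO1)N1CC(c2nc(-c3cccc(Cl)c3)no2)C1` share one core and differ only in the group on the carbonyl carbon. In an assay on HEK293 cells for negative allosteric modulation of metabotropic glutamate receptor 5 (Homo sapiens), read by FLIPR (on this read-out lower numbers stand for stronger inhibition and higher numbers for weaker inhibition), compound 2 gives 780 nM, and compound 1 gives 890 nM. The step of a 1.1-fold lower number from compound 1 to compound 2 (0.06 log units; within the scatter) is small, so compound 2 shows the lower of the two numbers without being separated from compound 1 beyond the scatter. Compound 3 `CC1CCN(C(=O)N2CC(c3nc(-c4cccc(Cl)c4)no3)C2)C1` has not yet been measured; it differs from compound 2 in a single place: 3-methylpyrrolidin-1-yl in place of 3-fluorophenyl on a carbonyl carbon. Among the measured compounds shown here, only one measured step bears on this change, a 1.1-fold lower number from compound 1 to compound 2 (0.06 log units; within the scatter), which exchanged a five-membered non-aromatic ring for the 3-fluorophenyl group at the same carbonyl carbon and left the number essentially where it was. Since compound 3 again carries a five-membered non-aromatic ring at that carbon, a step of similar size is expected from compound 2 to compound 3, a 1.4-fold higher number from compound 2 to compound 3 (0.15 log units; within the scatter), with no direction beyond the scatter claimed. The estimate for compound 3 in this assay is therefore 1100 nM, within a range from 450 nM to 2800 nM.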

Compound 3, half-maximal inhibitory concentration: > 10000 nM
Compound 3: a limit, no number; the forecaster's own chance of this, stated with the estimate: 5%; at least 9.0-fold (0.95 log units) between middle value and limit.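

In this assay compound 3 gives > 10000 nM, which is a limit of the assay and not a number: the limit of > 10000 nM in this assay, at which 1 of the 3 values shown sits. Measured against the 3-fluorophenyl group, 3-methylpyrrolidin-1-yl on this carbonyl carbon brings an at least 12-fold higher number from compound 2 to compound 3 (1.10 log units; beyond the scatter), and measured against oxolan-2-yl it brings an at least 11-fold higher number from compound 1 to compound 3 (1.05 log units; beyond the scatter). Compounds 1 and 2 alone showed two quite different groups at this carbonyl carbon with numbers within the scatter of each other, whereas compound 3 shows that the position does not accept every group and that a five-membered non-aromatic ring there does not by itself keep the number.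

The compounds shown leave open whether the loss goes with the methyl group or with the ring nitrogen joined to the carbonyl carbon, and how far beyond the limit compound 3 lies. A plain pyrrolidin-1-yl group, or an open-chain amine such as dimethylamino, on the same carbonyl carbon would bear on the first of these questions.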